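A few compounds are considered here, and "the series" means these few. Any claim that something is new, unique, unknown or untested is made for them only; others in the source may bear on it.

Measured so far:
- compound 1, `S=c1oc(-c2ccc3c(c2)OCCO3)nn1CN1CCN(C(c2ccccc2)c2ccccc2)CC1` — 21600 nM
- compound 2, `Cc1ccc(N2CCN(Cn3nc(-c4ccc5c(c4)OCCO5)oc3=S)CC2)c(C)c1` — > 50000 nM

In a functional assay on SW 1116 cells (Homo sapiens) for antiproliferative activity, read by MTT assay, with a stated time of 48 h (on this read-out lower numbers stand for stronger inhibition and higher numbers for weaker inhibition), compound 1 gives 21600 nM. For compound 2 only a limit is recorded: in this assay compound 2 gives > 50000 nM, a limit of the assay and not a number. Where compound 2 stands is therefore known only from one side, (the limit of > 50000 nM in this assay, at which 1 of the 2 values shown sits). Among the measured compounds shown here, of the two values shown, compound 1 is the one with a number, and compound 2 sits at the limit.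

Compound 3, `Fc1ccccc1N1CCN(Cn2nc(-c3ccc4c(c3)OCCO4)oc2=S)CC1`, has not yet been measured in this assay. It differs from compound 2 in one place: 2-fluorophenyl in place of 2,4-dimethylphenyl on an amine nitrogen in a ring. For the measured compounds named here, no measured pair shows a change of this kind, so the size of the step cannot be read from the data; with compound 2 itself at a limit, only a small gain beyond the scatter, if any, can be expected. The step from compound 2 to compound 3 is estimated as an at least 1.2-fold lower number from compound 2 to compound 3 (0.09 log units; that floor lies within the scatter). Compound 3 is expected to give 40000 nM, within a range from 10000 nM to 120000 nM.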

Compound 3, half-maximal inhibitory concentration: 37800 nM
Beside the measured number, compound 3's estimate is 1.1-fold (0.02 log units) above it, within the range that was stated.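

In this assay, placing 2-fluorophenyl in place of 2,4-dimethylphenyl on an amine nitrogen in a ring gives an at least 1.3-fold lower number from compound 2 to compound 3 (0.12 log units; that floor lies within the scatter). Among the compounds shown here, this is the first sign that this position can carry a group with a measured number, as compound 3 gives 37800 nM with the shared core unchanged. The size of the step can be stated only as a floor, and no larger change can be claimed, because compound 2 has a limit of the assay and not a number: the limit of > 50000 nM in this assay, at which 1 of the 3 values shown sits.

The compounds shown leave open whether the fluorine or the loss of the two methyl groups matters more, since the change alters both at once. They also leave open whether a plain phenyl, a benzyl group, or a phenyl bearing an amine or a carboxylic acid on the same nitrogen would give a number clearly apart from that of compound 3 in this assay.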